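The compounds below may be only part of what the source reports. "The series", "measured", "known", "first", "only" and "open" are said of these compounds alone.

Compound 1 `Cc1c(O)ccc2c1[C@H](Cn1cc(-c3ccccc3)nn1)[C@@]13CC(=O)[C@@](C)(CC[C@@H]21)C3` gives > 20000 nM in a functional assay on A549 cells (Homo sapiens) for cytotoxicity, read by MTT assay, with a stated time of 4 days (on this read-out higher numbers stand for weaker inhibition and lower numbers for stronger inhibition), which is a limit of the assay rather than a number.
Compound 2 `Cc1c(O)ccc2c1[C@H](Cn1cc(-c3ccccn3)nn1)[C@@]13CC(=O)[C@@](C)(CC[C@@H]21)C3` gives > 20000 nM in this assay, again a limit.
Compound 3 `C=C1C[C@]23C[C@@]1(O)CC[C@@H]2c1cccc(C)c1[C@@H]3Cn1cc(-c2ccccn2)nn1` gives > 20000 nM in this assay, also a limit.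

From compound 2 to compound 1 one change is made: phenyl in place of pyridin-2-yl on an aromatic carbon. The step that the two limits leave unreadable from compound 2 to compound 1 cannot be read, because both values sit at the limit of > 20000 nM in this assay, at which 3 of the 3 values shown sit. Compound 3 carries a different core, and the difference between the two cores is not broken down here. Compound 4 `C=C1C[C@]23C[C@@]1(O)CC[C@@H]2c1cccc(C)c1[C@@H]3Cn1cc(-c2ccccc2)nn1` arises from compound 3 by the same change: phenyl in place of pyridin-2-yl on an aromatic carbon. The step from compound 3 to compound 4 is expected to be a step that the limit leaves unreadable from compound 3 to compound 4, resting on compound 3 giving only the limit > 20000 nM and on the earlier step being unreadable. Compound 4 is therefore estimated at 30000 nM in this assay, most likely reported again only as a limit.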

Compound 4, half-maximal inhibitory concentration: > 20000 nM
Compound 4 was reported as a limit; the forecaster's own chance of this, stated with the estimate: 85%; the middle value does not contradict the limit.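

No size can be read for the change from compound 3 to compound 4, because both compounds sit at the same point: the limit of > 20000 nM in this assay, at which 4 of the 4 values shown sit. On these data alone, whether phenyl and pyridin-2-yl differ at all on either core in this assay stays open.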